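Hydroxy and Bromine Replace Nitro on the Hydrazone Aryl

The compounds below may be only part of what the source reports. "The series", "measured", "known", "first", "only" and "open" are said of these compounds alone.

Of the compounds shown here, three sharing one core have been measured in a functional assay on HepG2 cells (Homo sapiens) for cytotoxicity, read by MTT assay, with a stated time of 48 h; on this read-out higher numbers stand for weaker inhibition and lower numbers for stronger inhibition. Compound 1 `O=C(CSc1nnc(-c2ccncc2)o1)N/N=C/c1ccccc1` gives 17300 nM. Compound 2 `O=C(CSc1nnc(-c2ccncc2)o1)N/N=C/c1ccc(O)cc1` gives 5510 nM, and compound 3 `O=C(CSc1nnc(-c2ccncc2)o1)N/N=C/c1ccccc1[N+](=O)[O-]` gives 24700 nM. Compound 3 carries the highest number of the three: it sits closest to compound 1, and the step of a 1.4-fold higher number from compound 1 to compound 3 (0.15 log units; within the scatter) stays within the scatter, while the step of a 4.5-fold higher number from compound 2 to compound 3 (0.65 log units; beyond the scatter) lies beyond it. The step of a 3.1-fold lower number from compound 1 to compound 2 (0.50 log units; beyond the scatter) shows that the hydroxy group alone lowered the number by a modest amount.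

Compound 4 `O=C(CSc1nnc(-c2ccncc2)o1)N/N=C/c1cc(Br)ccc1O` differs from compound 3 in one place: 5-bromo-2-hydroxyphenyl in place of 2-nitrophenyl on a carbon with a double bond to nitrogen. Going by the values given here, two measured steps bear on this. The loss of the nitro group is mirrored by the within-scatter step from compound 1 to compound 3, so removing it is not expected to move the number much. The arrival of a hydroxy group resembles the step from compound 1 to compound 2, which was modest and downward. Nothing measured speaks to the bromine. Compound 4 is therefore expected to give a modestly lower number than compound 3, the step of a 2.7-fold lower number from compound 3 to compound 4 (0.44 log units; beyond the scatter) being the estimated size. Compound 4 is estimated at 9000 nM, within a range from 3500 nM to 23000 nM.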

Compound 4, half-maximal inhibitory concentration: 6490 nM
Compound 4: the middle estimate sits 1.4-fold (0.14 log units) above what was measured; low and high end bracket the measured number.
By their numbers in this assay, from the lowest: compounds 2 and 4 (each within the scatter of the next); then compounds 1 and 3 (each within the scatter of the next).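

In this assay, the carbon with a double bond to nitrogen accepts 5-bromo-2-hydroxyphenyl as readily as 4-hydroxyphenyl: the step (a 1.2-fold higher number from compound 2 to compound 4 (0.07 log units; within the scatter)) stays within the scatter, so the two cannot be told apart, even though the enters-and-leaves change here involves a bromine and a different hydroxyphenyl group. Both other steps lie beyond the scatter, one against the plain phenyl (a 2.7-fold lower number from compound 1 to compound 4 (0.43 log units; beyond the scatter)) and one against 2-nitrophenyl (a 3.8-fold lower number from compound 3 to compound 4 (0.58 log units; beyond the scatter)), so among these four compounds the two aryl groups bearing a hydroxy group both give lower numbers than the two without one, and no compound shown goes against this. No supporting measurement is available to explain these numbers.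

What the bromine and the hydroxy group of 5-bromo-2-hydroxyphenyl each contribute on their own stays open, since the compounds shown include neither the same ring with the hydroxy group alone nor with the bromine alone. Also open, from the compounds shown here alone, is how an amine, a methoxy group or a carboxylic acid in place of that hydroxy group would read on this assay.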